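The source may hold more compounds than are shown below. What is called first, only, known or untested is meant among the compounds shown, and "the series" means these compounds.

Compound 2 `CC(C)(C)c1ccc(-c2ccc3c(NCCCNCc4ccco4)ccnc3c2)cc1` gives 32000 nM in a physicochemical assay for solubility, with a stated time of 18 h, at pH 7.4; on this read-out higher numbers stand for higher solubility and lower numbers for lower solubility. It stands level with compound 1 `COc1cccc(CNCCCNc2ccnc3cc(-c4ccc(C(C)(C)C)cc4)ccc23)c1O`, which gives 32000 nM, and with compound 3 `COc1ccc(F)cc1CNCCCNc1ccnc2cc(-c3ccc(C(C)(C)C)cc3)ccc12`, which gives 32000 nM; the steps of no change at the digits printed from compound 1 to compound 2 (within the scatter), no change at the digits printed from compound 1 to compound 3 (within the scatter) and no change at the digits printed from compound 2 to compound 3 (within the scatter) all vary the group on the saturated chain carbon bound to an amine nitrogen. Compound 4 `c1coc(CNCCCNc2ccnc3cc(-c4cccc5ccccc45)ccc23)c1` differs from compound 2 elsewhere: naphthalen-1-yl in place of 4-(tert-butyl)phenyl on an aromatic carbon. Within the data shown here, no measured step touches this part of the shared core, so none bears directly on the change; the three steps within the scatter show only that the read-out has been flat across this small set. Compound 4 is therefore expected to stay within the scatter, with no change at the digits printed from compound 2 to compound 4 (within the scatter). The estimate for compound 4 is 32000 nM, in the range 12000 nM to 64000 nM.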

Compound 4, solubility: 32000 nM
Estimate against measurement, compound 4: no gap at the digits printed, and the stated range covers the measured number.
By their numbers in this assay, from the lowest: compounds 1, 2, 3 and 4 (each within the scatter of the next).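

Among these compounds, the first change at this aromatic carbon, naphthalen-1-yl in place of 4-(tert-butyl)phenyl, gives no change at the digits printed from compound 2 to compound 4 (within the scatter) in this assay. The earlier steps shown here varied only the group on the saturated chain carbon; this one shows that the read-out also holds level when one carbon-only group of 10 heavy atoms replaces another at this second position, even with 2 six-membered aromatic rings in place of one. No measured evidence accounts for this result.

As far as these compounds go, both groups at this position are carbon only, so it remains open whether an amine or a carboxylic acid there would shift the read-out.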